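The source may hold more compounds than are shown below. What is called first, only, known or untested is meant among the compounds shown, and "the series" means these compounds.

Measured compounds:
compound 1, `O=C(CCNCc1cc(Cl)c2cccnc2c1O)Nc1ccccc1`: 3500 nM
compound 2, `CN(CCCCCC(=O)Nc1ccc(O)c2ncccc12)c1ccccc1`: > 10000 nM

Of the compounds shown here, two have been tested in an assay on isolated protein for inhibition of matrix metalloproteinase-9 (Homo sapiens), read by colorimetric assay, with stated times of 30 min and 20 min; on this read-out higher numbers stand for weaker inhibition and lower numbers for stronger inhibition. Compound 1 gives 3500 nM. For compound 2 the result is > 10000 nM, which is a limit of the assay rather than a number. Among the values shown, (the limit of > 10000 nM in this assay, at which 1 of the 2 values shown sits). Compound 3, `CN(CCCCC(=O)Nc1ccc(O)c2ncccc12)c1ccccc1`, has not yet been measured. It differs from compound 2 in one place: methyl(phenyl)amino in place of (methyl(phenyl)amino)methyl on a saturated chain carbon, four bonds along the chain from a carbonyl carbon. For the measured compounds named here, no pair of measured compounds differing in only one place is available, so there is no measured step to lean on for this change. The expectation is that the change moves the value by no more than the usual scatter, so the step that the limit leaves unreadable from compound 2 to compound 3 is expected to be small in either direction, and the result may again be a limit. Compound 3 is therefore estimated at 15000 nM, with a range from 5000 nM to 50000 nM.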

Compound 3, half-maximal inhibitory concentration: > 10000 nM
Compound 3: a limit, no number; the forecaster's own chance of this, stated with the estimate: 70%; the middle value is on the limit's open side.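

For the compounds shown here, compound 2 and compound 3 each give only a limit of the assay, not a number, so no step between them can be read. The compounds shown leave open whether methyl(phenyl)amino in place of (methyl(phenyl)amino)methyl changes the inhibition at all.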